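This account rests on a few compounds, and the source may have more. Where it says the series, first, only, none or still open, it means among the compounds named here.

Measured so far:
compound 1 `CC(=O)Oc1ccccc1C(=O)O[C@H]1CO[C@H]2[C@@H]1OC[C@H]2OC(=O)c1ccnn1C` — 0.0642 h
compound 2 `CCOc1cc(OCC)cc(C(=O)O[C@@H]2CO[C@H]3[C@@H]2OC[C@@H]3OC(=O)c2ccccc2OC(C)=O)c1` — 0.0283 h

Compound 2 `CCOc1cc(OCC)cc(C(=O)O[C@@H]2CO[C@H]3[C@@H]2OC[C@@H]3OC(=O)c2ccccc2OC(C)=O)c1` shows the lowest of the two numbers in an ADME assay on a cell-free system (plasma, Homo sapiens) for metabolic stability, with Plasma (Rattus norvegicus) as the target, read by HPLC, at pH 7.4 (on this read-out lower numbers stand for a shorter-lived compound and higher numbers for a longer-lived compound), and gives 0.0283 h; its nearest neighbour is compound 1 `CC(=O)Oc1ccccc1C(=O)O[C@H]1CO[C@H]2[C@@H]1OC[C@H]2OC(=O)c1ccnn1C`, which in this assay gives 0.0642 h. Among the compounds with values here, the one measured step, a 2.3-fold lower number from compound 1 to compound 2 (0.36 log units; beyond the scatter), is modest and concerns a different replacement at the same carbonyl carbon.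

Compound 3 `CC(=O)Oc1ccccc1C(=O)O[C@H]1CO[C@H]2[C@@H]1OC[C@H]2OC(=O)c1ccccc1CO[N+](=O)[O-]` differs from compound 2 in one place: 2-((nitrooxy)methyl)phenyl in place of 3,5-diethoxyphenyl on a carbonyl carbon. Within the data shown here, no measured step involves the entering group, so the only guide is the size of the step already seen at this position, which was modest. Compound 3 is therefore expected to land near compound 2, with a step of about a 1.4-fold higher number from compound 2 to compound 3 (0.15 log units; within the scatter) in either direction, likely within or just beyond the scatter. Compound 3 is estimated at 0.04 h, within a range from 0.015 h to 0.12 h.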

Compound 3, half-life: 0.0533 h
Compound 3: middle estimate off by 1.3-fold (0.12 log units), on the low side, and the stated range covers the measured number.
By their numbers in this assay, from the lowest: compounds 2, 3 and 1 (each within the scatter of the next, the first and the last beyond it).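

In this assay, 2-((nitrooxy)methyl)phenyl on this carbonyl carbon gives a 1.9-fold higher number from compound 2 to compound 3 (0.27 log units; within the scatter) and a 1.2-fold lower number from compound 1 to compound 3 (0.08 log units; within the scatter), so it cannot be told apart from either 3,5-diethoxyphenyl or 1-methyl-1H-pyrazol-5-yl. Compound 3 thus lies within the scatter of both compound 1 and compound 2, although those two lie beyond the scatter of each other, and the three quite different groups at this position span little more than that scatter. Nothing available explains these readings.

The compounds shown leave open whether a plain phenyl, or an amine or carboxylic acid on the ring, would take the half-life outside this narrow span. From the compounds shown here alone, whether the nitrooxy part or the phenyl ring carrying it sets the reading of compound 3 also remains open.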